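One core change, measured twice across two side chains

The source may report more compounds than this note shows. Statements on the series, on what has been measured and on what is new or still open speak of the compounds shown alone.

Three measured compounds share a common core and differ only in their peripheral groups. Compound 1 `FC(F)(F)c1ccc(-c2ccc3c(NCCCNCc4ccco4)ccnc3c2)cc1` gives 9.47 in a physicochemical assay for acid dissociation. Compound 2 `c1ccc(Cc2ccc3c(NCCCNCc4ccco4)ccnc3c2)cc1` differs from compound 1 only by one change, (benzyl in place of 4-(trifluoromethyl)phenyl on an aromatic carbon), and in this assay compound 2 gives 9.47; the step of no change at the digits printed from compound 1 to compound 2 (within the scatter). Compound 3 `COc1cccc(CNCCCNc2ccnc3cc(-c4ccc(C(F)(F)F)cc4)ccc23)c1O` keeps the core of compound 1 but carries a different group on the amine end of the chain, the difference being (2-hydroxy-3-methoxyphenyl in place of furan-2-yl on a saturated chain carbon bound to an amine nitrogen). In this assay compound 3 gives 9.47, and the step of no change at the digits printed from compound 1 to compound 3 (within the scatter). Compound 4 `COc1cccc(CNCCCNc2ccnc3cc(Cc4ccccc4)ccc23)c1O` has not yet been measured. It stands to compound 3 exactly as compound 2 stands to compound 1: the change is benzyl in place of 4-(trifluoromethyl)phenyl on an aromatic carbon, the same change made at the same place. Because compound 1 showed no change at the digits printed from compound 1 to compound 2 (within the scatter) under that matching change, the expected step is no change at the digits printed from compound 3 to compound 4 (within the scatter) in this assay, beside the earlier one. On that basis compound 4 is expected to give 9.47 in this assay, estimated to fall between 9.15 and 9.8.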

Compound 4, acid dissociation constant: 9.47
Estimate against measurement, compound 4: no gap at the digits printed; the measured number falls inside the stated range.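

In this assay, benzyl in place of 4-(trifluoromethyl)phenyl on an aromatic carbon gives no change at the digits printed from compound 3 to compound 4 (within the scatter) and, on the furan-2-yl side chain, gave no change at the digits printed from compound 1 to compound 2 (within the scatter); the swap of side chain likewise gives no change at the digits printed from compound 2 to compound 4 (within the scatter) on the benzyl compounds. The change therefore carries over between these two side chains with the same outcome, and all four compounds form a closed square in which neither change moves the read-out at the digits printed. Within the data shown here, this does not show that the result holds on any other core or side chain, and a square with no step in it offers no effect whose transfer could be tested, only the same absence twice; no evidence is available that bears on the result.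

The compounds shown leave open whether a carboxylic acid or an amine on that aromatic carbon, or a longer chain carrying the amine nitrogen, would read the same in this assay. They also say nothing of how either change behaves in any other kind of measurement.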